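A Ring Group Exchanged, Half-Life Still Unknown

The compounds below may be only part of what the source reports. "The series", "measured", "known", "first", "only" and "open" are said of these compounds alone.

Of the compounds shown here, three so far have numbers in an in vitro ADME assay on microsomes from liver (Homo sapiens) for metabolic stability, tested at 5 uM (on this read-out lower numbers stand for a shorter-lived compound and higher numbers for a longer-lived compound), to compare. Compound 1 (`CC(C)CCn1nc(-c2cccs2)c(O)c(C2=NS(=O)(=O)c3cc(N(C)S(C)(=O)=O)ccc3N2)c1=O`) gives 0.467 h and compound 2 (`CS(=O)(=O)Nc1ccc2c(c1)S(=O)(=O)N=C(c1c(O)c(-c3ccsc3)nn(CCC3CC3)c1=O)N2`) gives 0.517 h while compound 3 (`CC(C)CCn1nc(-c2ccn(C)c2)c(O)c(C2=NS(=O)(=O)c3cc(NS(C)(=O)=O)ccc3N2)c1=O`) gives 0.633 h in the same test. All three lie within the usual scatter of one another, so compound 3 stands level with the other two. Compound 4 (`CC(C)CCn1nc(CC2=CCCC2)c(O)c(C2=NS(=O)(=O)c3cc(NS(C)(=O)=O)ccc3N2)c1=O`) carries (cyclopent-1-en-1-yl)methyl in place of 1-methyl-1H-pyrrol-3-yl on an aromatic carbon and is otherwise the same as compound 3. Within the data shown here, no measured pair differs in one place only, so nothing shows this step directly. The estimated step is a 1.4-fold lower number from compound 3 to compound 4 (0.15 log units; within the scatter) and is expected to be a slight drop within the scatter. For compound 4 the expected half-life is 0.45 h with an estimated range from 0.22 h to 0.9 h in this assay here.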

Compound 4, half-life: 0.15 h
Compound 4: the middle estimate sits 3.0-fold (0.48 log units) above what was measured; measured number outside the range, below it.
By their numbers in this assay, from the lowest: compound 4; then compounds 1, 2 and 3 (each within the scatter of the next).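

In this assay this aromatic carbon proves sensitive to what it carries: exchanging 1-methyl-1H-pyrrol-3-yl for (cyclopent-1-en-1-yl)methyl brings a 4.2-fold lower number from compound 3 to compound 4 (0.63 log units; beyond the scatter) and so a real loss of half-life. The two groups have the same number of heavy atoms, so size by that count does not separate them; what differs is an aromatic ring with nitrogen against a non-aromatic carbon ring. Nothing measured here explains the drop.

Still open, as far as these compounds go, is whether the loss follows the aromatic ring or the ring's attachment through a carbon link. A phenyl or cyclopentyl group placed directly on this carbon would help separate those two readings.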